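From isobutyl to 4-bromophenyl at an assay limit

The source may report more compounds than this note shows. Statements on the series, on what has been measured and on what is new or still open speak of the compounds shown alone.

Compound 1 (`COc1cc(-c2nccn2CC(C)C)cc(OC)c1OC`) has an isobutyl group on an aromatic nitrogen of the shared core. In a functional assay on HCT-15 cells (Homo sapiens) for antiproliferative activity, read by MTT assay, with a stated time of 72 h (a lower number here means a stronger inhibitor, a higher number a weaker inhibitor), compound 1 gives > 100000 nM, which is a limit of the assay and not a number. Compound 2 (`COc1cc(-c2nccn2S(=O)(=O)c2ccccc2)cc(OC)c1OC`) gives > 100000 nM, and this too is a limit. Within the data shown here, compound 1 therefore has no exact value to start from, and the only other measurement offers none either. Among the measured compounds shown here, no measured step shows how much a change on this nitrogen can matter.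

Compound 3 (`COc1cc(-c2nccn2-c2ccc(Br)cc2)cc(OC)c1OC`) carries 4-bromophenyl in place of isobutyl on that aromatic nitrogen (4-bromophenyl in place of isobutyl on an aromatic nitrogen). Compound 2 also has a six-membered aromatic ring within its group on this nitrogen, yet it stays at a limit, so any expectation of a gain must be cautious. The estimated step in this assay is an at least 5.0-fold lower number from compound 1 to compound 3 (0.69 log units; beyond the scatter), towards stronger inhibition and beyond the usual scatter, although another limit would be no surprise. For compound 3, the expected value is 20000 nM, with an estimated range from 2500 nM to 100000 nM.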

Compound 3, half-maximal inhibitory concentration: 11700 nM
The estimate for compound 3 lay 1.7-fold (0.23 log units) above the measured number; low and high end bracket the measured number.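

In this assay, 4-bromophenyl in place of isobutyl gives an at least 8.5-fold lower number from compound 1 to compound 3 (0.93 log units; beyond the scatter), so a change on this aromatic nitrogen can move the number by more than the usual variation between repeated measurements. Compound 3, at 11700 nM, is also the only compound shown with an exact value, which gives any further change on this nitrogen a real number for comparison. The step itself is a minimum and not a full size, because its starting point is a limit of the assay and not a number: the limit of > 100000 nM in this assay, at which 2 of the 3 values shown sit.

The compounds shown leave open whether the gain comes from the six-membered aromatic ring or from the bromine it carries, since the two enter together in compound 3. A plain phenyl group on this nitrogen would separate those two shares, while a 4-methoxyphenyl or 4-aminophenyl group would show whether the bromine can be replaced by another group and whether the number then rises, falls or stays within the scatter.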